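This account rests on a few compounds, and the source may have more. Where it says the series, first, only, none or still open, it means among the compounds named here.

Measured compounds:
compound 1 `O=C(/C=C/c1ccc([N+](=O)[O-])cc1)c1ccc(O)c(O)c1` – 28000 nM
compound 2 `CC(=O)Nc1ccc(C(=O)/C=C/c2cccc([N+](=O)[O-])c2)cc1` – 15000 nM

In a toxicity assay on FHC cells (Homo sapiens) for cytotoxicity, read by resazurin assay, with a stated time of 48 h (on this read-out lower numbers stand for higher toxicity in this test and higher numbers for lower toxicity in this test), compound 2 gives the lowest of the two numbers, and compound 1 gives a number that is higher, though the two lie within the scatter of each other. Compound 3 `O=C(/C=C/c1cccc([N+](=O)[O-])c1)c1ccc(NC(=O)c2ccccc2)cc1` differs from compound 2 in one place: phenyl in place of methyl on a carbonyl carbon. For the measured compounds named here, no measured pair shows the effect of this change, so the step from compound 2 to compound 3 in this assay is expected to stay within the scatter, in no clear direction. The step of a 1.3-fold lower number from compound 2 to compound 3 (0.10 log units; within the scatter) is expected to be small. Compound 3 is estimated at 12000 nM, with a range from 4000 nM to 40000 nM.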

Compound 3, half-maximal cytotoxic concentration: > 100000 nM
Compound 3 gave a limit, no number; the forecaster's own chance of this, stated with the estimate: 10%; at least 8.3-fold (0.92 log units) between middle value and limit.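

In this assay, for the compounds shown here, phenyl in place of methyl on a carbonyl carbon gives an at least 6.6-fold higher number from compound 2 to compound 3 (0.82 log units; beyond the scatter), so the read-out does respond to the group at this place, which the earlier compounds could not show. Compound 3 gives > 100000 nM, which is a limit of the assay and not a number. The step therefore rests on a limit: the limit of > 100000 nM in this assay, at which 1 of the 3 values shown sits.

This single pair leaves open where compound 3 would fall as a number. It also leaves open whether an ethyl chain or a cyclohexyl ring on this carbonyl carbon would move the read-out as phenyl does.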